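Notes on the amine substituent of the shared core

This account rests on a few compounds, and the source may have more. Where it says the series, first, only, none or still open, it means among the compounds named here.

Measured so far in a functional assay on DU-145 cells (Homo sapiens) for cytotoxicity, read by MTT assay, with a stated time of 72 h; on this read-out lower numbers stand for an effect already at smaller amounts and higher numbers for an effect only at larger amounts of compound:
compound 1 `Cc1ccc(Nc2cc(-c3ccccc3)oc(=O)c2)cc1` — 0.073 uM
compound 2 `O=c1cc(NC2CCCCC2)cc(-c2ccccc2)o1` — 7.47 uM

Compound 2 stands highest of the two numbers in this assay; its nearest neighbour is compound 1, which gives 0.073 uM. Compound 3 `O=c1cc(Nc2ccc(Br)cc2)cc(-c2ccccc2)o1` differs from compound 2 by 4-bromophenyl in place of cyclohexyl on a nitrogen on an aromatic ring. Among the measured compounds shown here, the single measured step that bears on this change is a 100-fold higher number from compound 1 to compound 2 (2.01 log units; beyond the scatter), and it runs the opposite way, an aromatic ring giving way to cyclohexyl. Since compound 3 puts an aromatic ring back on that nitrogen, a large step down is expected, a 50-fold lower number from compound 2 to compound 3 (1.70 log units; beyond the scatter). For compound 3 the estimate is 0.15 uM, expected to fall between 0.03 uM and 0.8 uM.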

Compound 3, concentration for half-maximal effect: 0.34 uM
Beside the measured number, compound 3's estimate is 2.3-fold (0.36 log units) below it; measured number inside the range.
By their numbers in this assay, from the lowest: compound 1; then compound 3; then compound 2.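

In this assay, the advantage of an aromatic ring over cyclohexyl on this nitrogen now holds for a second aromatic group, with a 22-fold lower number from compound 2 to compound 3 (1.34 log units; beyond the scatter). The ring's own substituent also matters, though less, with bromo in place of methyl giving a 4.7-fold higher number from compound 1 to compound 3 (0.67 log units; beyond the scatter). No evidence here accounts for either step.

Open, as far as these compounds go, is whether a carboxylic acid or an amine in place of bromo or methyl keeps the number low. Also open, from the compounds shown here alone, is whether a longer chain on that nitrogen behaves as cyclohexyl does.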